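The source may report more compounds than this note shows. Statements on the series, on what has been measured and on what is new or still open speak of the compounds shown alone.

Measured compounds:
- compound 1 `Cc1cccc(C)c1NC(=O)Nc1ccncc1`: 30 mg/kg
- compound 2 `Cc1cccc(C)c1NC(=O)Nc1ccccn1`: 300 mg/kg
- compound 3 `Cc1cccc(Cl)c1NC(=O)Nc1ccccn1`: 100 mg/kg

The read-out throughout is a functional assay on the whole organism with Mus musculus as the target, in the maximal electroshock model, with a stated time of 30 min; on this read-out lower numbers stand for an effect already at smaller amounts and higher numbers for an effect only at larger amounts of compound. Among the three measured compounds, compound 2 stands highest in this assay; its nearest neighbour is compound 3, with a 3.0-fold lower number from compound 2 to compound 3 (0.48 log units; beyond the scatter), and the furthest is compound 1, with a 10-fold higher number from compound 1 to compound 2 (1.00 log units; beyond the scatter) separating the two.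

Compound 4 `Cc1cccc(C)c1NC(=O)Nc1cccnc1` is not yet measured. It differs from compound 2 in one place: pyridin-3-yl in place of pyridin-2-yl on an amide-type nitrogen. Going by the values given here, the only measured step that bears on the position of the ring nitrogen is the one from compound 1 to compound 2, where pyridin-2-yl in place of pyridin-4-yl gave a 10-fold higher number from compound 1 to compound 2 (1.00 log units; beyond the scatter). Among the compounds with values here, no measured pair shows pyridin-3-yl directly, so the account rests on that single step. Since pyridin-2-yl gave the highest number and pyridin-4-yl the lowest, pyridin-3-yl is expected to fall between them, giving a lower number than compound 2 by a modest margin. The step from compound 2 to compound 4 is therefore expected to be a 3.0-fold lower number from compound 2 to compound 4 (0.48 log units; beyond the scatter). Compound 4 is estimated at 100 mg/kg in this assay, with a range from 30 mg/kg to 300 mg/kg.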

Compound 4, minimum effective dose: 100 mg/kg
Estimate against measurement, compound 4: no gap at the digits printed; measured number inside the range.
By their numbers in this assay, from the lowest: compound 1; then compounds 3 and 4 (each within the scatter of the next); then compound 2.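

In this assay the position of the ring nitrogen now has a third point, with a 3.0-fold lower number from compound 2 to compound 4 (0.48 log units; beyond the scatter) and a 3.3-fold higher number from compound 1 to compound 4 (0.52 log units; beyond the scatter), so pyridin-3-yl stands apart from both other pyridinyl groups. With the rest of the molecule held fixed, the numbers rise from pyridin-4-yl through pyridin-3-yl to pyridin-2-yl, although pyridin-3-yl and pyridin-2-yl have the same counts of heavy atoms, hydrogen-bond donors and hydrogen-bond acceptors. Nothing measured on these compounds accounts for this order.

Whether the same order holds with chloro in place of methyl remains open, since among the compounds shown chloro appears only with pyridin-2-yl. Also open, from the compounds shown here alone, is how a plain phenyl ring, or an amine on the pyridine ring, would read in this assay.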